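Cytotoxicity tolerance across the series and one planned replacement

This account rests on a few compounds, and the source may have more. Where it says the series, first, only, none or still open, it means among the compounds named here.

Compound 1 `CC(C)CCn1c(Cn2c(=O)n(C(C)C)c3ccccc32)nc2cc(CNC3CC3)ccc21` is the reference here. In an ADME assay on HEp-2 cells (Homo sapiens) for cytotoxicity (a lower number here means that less compound is tolerated, a higher number that more compound is tolerated), compound 1 gives 17200 nM, the highest of the three numbers at hand. Compound 3 `CC(C)CCn1c(Cn2c(=O)n(C(C)C)c3ccccc32)nc2cccc(CN)c21` gives 11000 nM in this assay, and this gap to compound 1 lies within the scatter. Within the data shown here, compound 2 `CC(C)CCn1c(Cn2c(=O)n(CC(=O)OC(C)(C)C)c3ccccc32)nc2cc(C(=N)N)ccc21` gives 7900 nM in this assay, the only gap from compound 1 that lies beyond the scatter. None of the three measured compounds differ from one another in a single place, so no single-point change has yet been followed in this assay.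

Compound 4 `CC(C)CCn1c(Cn2c(=O)n(C(C)C)c3ccccc32)nc2cc(-c3ncon3)ccc21` has not been measured. It differs from compound 1 in one place: 1,2,4-oxadiazol-3-yl in place of (cyclopropylamino)methyl on an aromatic carbon. Among the measured compounds shown here, nothing among the measured compounds tracks this kind of exchange, and the three values at hand sit close together. The expectation for compound 4 in this assay is therefore a step of a 1.1-fold lower number from compound 1 to compound 4 (0.06 log units; within the scatter), none beyond the scatter. Compound 4 is estimated at 15000 nM, in a range from 6000 nM to 35000 nM.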

Compound 4, half-maximal cytotoxic concentration: 223000 nM
For compound 4 the middle estimate is 15-fold (1.17 log units) below the measured one, outside the stated range (above it).
By their numbers in this assay, from the lowest: compounds 2, 3 and 1 (each within the scatter of the next, the first and the last beyond it); then compound 4.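

In this assay, exchanging the (cyclopropylamino)methyl group for a 1,2,4-oxadiazol-3-yl group gives a 13-fold higher number from compound 1 to compound 4 (1.11 log units; beyond the scatter), the first single-place step available in this series. Among these compounds, this position therefore has a large bearing on the read-out, which the earlier compounds could not show because they differ from one another in more than one place. The step comes with 5 heavy atoms on both sides, so heavy-atom count does not separate the two groups, while the hydrogen-bond donors go from 1 to 0 and the acceptors from 1 to 3; no measurement at hand accounts for the step.

From the compounds shown here alone, with a single exchange, it remains open whether the loss of the amine, the arrival of the aromatic ring or its hetero atoms goes with the step. A dimethylaminomethyl group or a phenyl ring at this place would begin to separate these features.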